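This account rests on a few compounds, and the source may have more. Where it says the series, first, only, none or still open, it means among the compounds named here.

Measured in a functional assay on K562 cells (Homo sapiens) for cytotoxicity, read by MTT assay, with a stated time of 5 days; on this read-out higher numbers stand for weaker inhibition and lower numbers for stronger inhibition:
Compound 1 `COc1ccc(Cn2nncc2-c2cc(OC)c(OC)c(OC)c2)cc1N`: 730 nM
Compound 2 `COc1ccc(-c2cnnn2Cc2cc(OC)c(OC)c(OC)c2)cc1Br`: > 10000 nM

For compound 2, this assay gives only a limit, > 10000 nM, and not a number. Compound 1, by contrast, gives a true number, 730 nM. Among the compounds with values here, these two compounds do not differ in just one place, so no measured step shows how much a single change can do here.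

Compound 3 `COc1ccc(-c2cnnn2Cc2cc(OC)c(OC)c(OC)c2)cc1[N+](=O)[O-]` keeps the core of compound 2 and changes one group: nitro in place of bromo on an aromatic carbon. This puts nitro in place of bromo on an aromatic carbon, ortho to a methoxy group.

The closest neighbour of compound 3 is compound 2. Compound 2 stays at the limit > 10000 nM, so no shift beyond the scatter is the likeliest outcome in this assay. The expected change is a number no higher from compound 2 to compound 3 (the limit leaves the size open). The estimate for compound 3 is 10000 nM, in an expected range from 3000 nM to 30000 nM.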

Compound 3, half-maximal inhibitory concentration: > 10000 nM
Compound 3 gave a limit, no number (the forecaster's own chance of this, stated with the estimate: 65%); the middle value sits exactly at the limit.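

Compound 2 and compound 3 both give only limits, not numbers, in this assay, so the change from bromo to nitro cannot be read as a step. The compounds shown leave open what true numbers lie behind these limits, and whether either group gives stronger inhibition.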